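Salicylanilide series: acetyl in place of trifluoromethyl

This account rests on a few compounds, and the source may have more. Where it says the series, first, only, none or still open, it means among the compounds named here.

Compound 1 `C/C(=N\OCC(=O)N[C@H](C(=O)N[C@@H](CCCCN)C(=O)N1CCC[C@H]1C(=O)N1CCC[C@@H]1C(=O)N[C@H](CCCNC(=N)N)C(=O)O)[C@@H](C)O)c1ccc(NC(=O)c2cc(Br)ccc2O)cc1` returns only a limit in a functional assay on MONO-MAC-6 cells (Homo sapiens) for cytotoxicity, read by MTT assay, with a stated time of 24 h (a higher number here means a weaker inhibitor, a lower number a stronger inhibitor), namely > 200000 nM; this is where the limit of > 200000 nM in this assay, at which 1 of the 2 values shown sits, sits. Among the compounds with values here, compound 2 `O=C(Nc1ccc(C(F)(F)F)cc1)c1cc(Br)ccc1O` gives 2000 nM in this assay, the single numeric value available, so it stands alone as the reference point. Compound 3 `CC(=O)c1ccc(NC(=O)c2cc(Br)ccc2O)cc1` is not yet measured and differs from compound 2 by acetyl in place of trifluoromethyl on an aromatic carbon. Within the data shown here, no measured step of this kind exists, so for compound 3 the expected step is a 1.5-fold higher number from compound 2 to compound 3 (0.18 log units; within the scatter), close to the usual scatter and, if anything, toward weaker inhibition. Compound 3 is estimated at 3000 nM, with a range from 800 nM to 12000 nM.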

Compound 3, half-maximal inhibitory concentration: 18600 nM
Beside the measured number, compound 3's estimate is 6.2-fold (0.79 log units) below it; measured number above the stated range.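

Within the data shown here, at this position, on an aromatic carbon para to a large group, acetyl in place of trifluoromethyl gives in this assay a 9.3-fold higher number from compound 2 to compound 3 (0.97 log units; beyond the scatter), the only measured step so far. The group here therefore moves the read-out beyond the scatter, toward weaker inhibition. Nothing measured here bears on the reason for this step. As far as these compounds go, whether an amine, a carboxylic acid or a nitrile at this position would read closer to trifluoromethyl or to acetyl stays open. So does whether a longer chain would extend the same trend.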